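Aryl Groups on the Shared Core at Adenosine Receptor A3

The compounds below may be only part of what the source reports. "The series", "measured", "known", "first", "only" and "open" are said of these compounds alone.

compound 1 `CC(C)(C)Cc1csc(N)c1C(=O)c1ccc(Cl)cc1`: 5%
compound 2 `CC(C)(C)Cc1c(-c2ccc(F)cc2F)sc(N)c1C(=O)c1ccc(Cl)cc1`: 1%
compound 3 `CC(C)(C)Cc1c(-c2c(F)cccc2F)sc(N)c1C(=O)c1ccc(Cl)cc1`: 1%

Three compounds share the core of compound 1 and were tested in an assay on CHO cells for displacement of a labelled ligand from adenosine receptor A3 (Homo sapiens), read by scintillation counting, tested at 10 uM; a higher number here means more inhibition at the concentration tested (going by the name of the read-out), a lower number less inhibition. Compound 1 carries a hydrogen where compound 2 and compound 3 carry a difluorophenyl group. Compound 1 serves as the reference point, and the steps of a number 4 percentage points lower from compound 1 to compound 2 (within the scatter) and a number 4 percentage points lower from compound 1 to compound 3 (within the scatter) are both within the scatter, so nothing separates the three numbers. Between the two aryl compounds there is likewise no change at the digits printed from compound 2 to compound 3 (within the scatter).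

Compound 4 `CC(C)c1ccc(-c2sc(N)c(C(=O)c3ccc(Cl)cc3)c2CC(C)(C)C)cc1` is the next member of the series. Compared with compound 1 it shows (4-isopropylphenyl in place of hydrogen on an aromatic carbon). For the measured compounds named here, the steps that bear on it are those from compound 1 to the two difluorophenyl compounds, both introducing an aryl group at the same position; neither moved the read-out beyond the scatter. With no aryl group in the series having shifted this assay, the expectation for compound 4 is a step of a number 2 percentage points lower from compound 1 to compound 4 (within the scatter), that is, no change beyond the scatter. Compound 4 is therefore estimated at 3%, within a range from 0% to 12%.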

Compound 4, a percentage reported as inhibition, at one concentration (the size of the read-out at that concentration, not a potency): 1%
For compound 4 the middle estimate is 2 percentage points above the measured one; the measured number falls inside the stated range.
By their numbers in this assay, from the lowest: compounds 2, 3, 4 and 1 (each within the scatter of the next).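

this assay shows a number 4 percentage points lower from compound 1 to compound 4 (within the scatter) when the 4-isopropylphenyl group takes the place of hydrogen on the aromatic carbon next to the ring sulfur, so an aryl group carrying no fluorine reads like the two difluorophenyl groups here. Exchanging either difluorophenyl group for 4-isopropylphenyl gives no change at the digits printed from compound 3 to compound 4 (within the scatter) and no change at the digits printed from compound 2 to compound 4 (within the scatter) in the same read-out, so neither the fluorine atoms nor the isopropyl group separates these compounds. Across hydrogen and three different aryl groups at this one position, the four numbers stay within the scatter of one another, and no group shown here moves this assay beyond it.

The compounds shown leave open whether a group of another kind at this position, such as a carboxylic acid, an amine or a longer alkyl chain, would move the number beyond the scatter. They also leave open whether replacing the neopentyl group or the (4-chlorophenyl)carbonyl group, both held fixed here, would do so.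

No further measurement is at hand that bears on this result.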